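Side-chain step from compound 2 to compound 3

The compounds below may be only part of what the source reports. "The series", "measured", "known", "first", "only" and "open" are said of these compounds alone.

compound 1 `CN(C)CCn1c(N)c(-c2nc3ccccc3n2C)c2nc(C#N)c(C#N)nc21`: > 50000 nM (a limit)
compound 2 `CCN(CC)CCn1c(N)c(-c2nc3ccccc3n2C)c2nc(C#N)c(C#N)nc21`: > 50000 nM (a limit)

Compound 2 gives > 50000 nM in a functional assay on HeLa cells (Homo sapiens) for antiproliferative activity, read by MTT assay, with a stated time of 48 h (a higher number here means a weaker inhibitor, a lower number a stronger inhibitor), and this value is a limit. For the measured compounds named here, the series so far offers only the limit of > 50000 nM in this assay, at which 2 of the 2 values shown sit, and no number.

Compound 3 `CN(C)CCCn1c(N)c(-c2nc3ccccc3n2C)c2nc(C#N)c(C#N)nc21` differs from compound 2 by (dimethylamino)methyl in place of diethylamino on a saturated chain carbon, two bonds along the chain from an aromatic nitrogen with (dimethylamino)methyl in place of diethylamino on a saturated chain carbon, two bonds along the chain from an aromatic nitrogen. Cut one bond further out, this reads 2-(diethylamino)ethyl to 3-(dimethylamino)propyl.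

Going by the values given here, the only measured step that bears on this place is a step that the two limits leave unreadable from compound 1 to compound 2 and it yields no size. No step beyond the scatter is therefore expected in this assay and no direction can be expected. The expected change is a step that the limit leaves unreadable from compound 2 to compound 3 on this reading. Compound 3 is estimated at 60000 nM with an expected range from 25000 nM to 150000 nM and a limit is the likeliest report.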

Compound 3, half-maximal inhibitory concentration: 4320 nM
Compound 3: the middle estimate sits 14-fold (1.14 log units) above what was measured; measured number outside the range, below it.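

For the compounds shown here, this position on the chain can move the read-out in this assay: compound 3 gives 4320 nM, the only number so far rather than a limit. With the dimethylamino end kept, (dimethylamino)methyl in place of dimethylamino gives an at least 11-fold lower number from compound 1 to compound 3 (1.06 log units; beyond the scatter), so the longer chain alone is enough for a change beyond the scatter. (Dimethylamino)methyl in place of diethylamino gives an at least 11-fold lower number from compound 2 to compound 3 (1.06 log units; beyond the scatter), but this step alters the amine end and the chain length together.

The step between compound 1 and compound 2 cannot be read, which leaves the effect of the amine end on the shorter chain unresolved, and both values remain limits: the limit of > 50000 nM in this assay, at which 2 of the 3 values shown sit. Also open, going by these compounds, are whether 3-(diethylamino)propyl holds this level and whether a longer chain, such as 4-(dimethylamino)butyl, or a morpholine at the chain end lowers the number further.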